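Trimming a sulfonamide: from dimethylamino to free amino

A few compounds are considered here, and "the series" means these few. Any claim that something is new, unique, unknown or untested is made for them only; others in the source may bear on it.

Among the compounds with values here, compound 2 `COc1ccc2c(c1)c(/C=C1\C(=O)Nc3ccc(S(=O)(=O)N(C)C)cc31)cn2C` is the weaker of the two compounds measured so far in an assay on isolated protein for inhibition of high affinity nerve growth factor receptor (Homo sapiens); a lower number here means a stronger inhibitor, a higher number a weaker inhibitor: compound 2 gives 10.1 nM, while compound 1 `Cn1cc(/C=C2\C(=O)Nc3ccc(S(N)(=O)=O)cc32)c2ccccc21` gives 4.17 nM. Compound 3 `COc1ccc2c(c1)c(/C=C1\C(=O)Nc3ccc(S(N)(=O)=O)cc31)cn2C` is the change (amino in place of dimethylamino on a sulfonyl sulfur), which carries the same sulfamoyl group found in compound 1, though the two compounds still differ elsewhere on the shared core. Within the data shown here, no single-change step between measured compounds is available, so the estimate rests on that comparison alone. For compound 3 a modest move toward a lower number is expected, a 1.8-fold lower number from compound 2 to compound 3 (0.26 log units; within the scatter), close to the scatter. Compound 3 is expected to give 5.5 nM, within 2 nM to 15 nM.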

Compound 3, half-maximal inhibitory concentration in the high affinity nerve growth factor receptor assay: 3.78 nM
Compound 3: middle estimate off by 1.5-fold (0.16 log units), on the high side, and the stated range covers the measured number.
By their numbers in the high affinity nerve growth factor receptor assay, from the lowest: compounds 3 and 1 (each within the scatter of the next); then compound 2.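

In the high affinity nerve growth factor receptor assay compound 2 gives 10.1 nM and compound 3 gives 3.78 nM, while amino in place of dimethylamino on a sulfonyl sulfur gives a 2.7-fold lower number from compound 2 to compound 3 (0.43 log units; beyond the scatter) on the methoxy-bearing core, so this position responds to the change. In the high affinity nerve growth factor receptor assay, the other step, a 1.1-fold lower number from compound 1 to compound 3 (0.04 log units; within the scatter) with the amino group kept, stays within the scatter, so methoxy in place of hydrogen shows no readable effect here. In a physicochemical assay for solubility, read by HPLC, with a stated time of 60 min (on this read-out lower numbers stand for lower solubility and higher numbers for higher solubility), compound 2 gives 7800 nM and compound 3 gives 9700 nM; the sulfonyl change gives a 1.2-fold higher number from compound 2 to compound 3 (0.09 log units; within the scatter) and also stays within the scatter. Going by these compounds, whether methylamino or morpholine on that sulfur would read like amino or like dimethylamino stays open. No measurement here explains why these numbers fall as they do.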